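A few compounds are considered here, and "the series" means these few. Any claim that something is new, unique, unknown or untested is made for them only; others in the source may bear on it.

Three compounds from this series have a number in an assay on M10 cells (Gallus gallus) for binding affinity to Neuronal acetylcholine receptor; alpha4/beta2 (Homo sapiens); on this read-out higher numbers stand for weaker inhibition and lower numbers for stronger inhibition. Compound 1 `[N-]=[N+]=Nc1cc(Cl)ncc1Cn1ccnc1N[N+](=O)[O-]` gives 16900 nM. Compound 3 `[N-]=[N+]=Nc1cc(Cn2ccs/c2=N\[N+](=O)[O-])cnc1Cl` gives 170 nM. Compound 2 `O=[N+]([O-])/C=C1\NC=CN1Cc1ccc(Cl)nc1` gives 60 nM, the lowest of the three values; the nearest to it is compound 3, whose number is higher by more than the scatter, and the furthest is compound 1, whose number is higher by a margin far beyond it. No two of these three differ from each other in a single place, so no single structural step can be read from them directly.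

Compound 4 `[N-]=[N+]=Nc1cc(CN2C=CN/C2=C\[N+](=O)[O-])cnc1Cl` is the compound that follows from compound 2 by one change: azido in place of hydrogen on an aromatic carbon. Compound 1 and compound 3 both carry an azido group on their own cores, and compound 3 still reaches 170 nM, so the change need not cost much. The expected step is a modest weakening, with the number for compound 4 estimated at 150 nM, within a range from 50 nM to 500 nM, which would mean a 2.5-fold higher number from compound 2 to compound 4 (0.40 log units; beyond the scatter).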

Compound 4, inhibition constant: 40 nM
Beside the measured number, compound 4's estimate is 3.8-fold (0.57 log units) above it; measured number outside the range, below it.
By their numbers in this assay, from the lowest: compounds 4 and 2 (each within the scatter of the next); then compound 3; then compound 1.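

In this assay, the step is a 1.5-fold lower number from compound 2 to compound 4 (0.18 log units; within the scatter), which lies within the scatter, so the azido group and the hydrogen it replaces cannot be told apart on this read-out. Among these compounds, this is the first direct reading of the change: compounds 1 and 3 also carry an azido group, but each on its own core and with no hydrogen counterpart, whereas here the group sits on the aromatic carbon ortho to a chloro group and two atoms from the ring nitrogen. Nothing at hand explains why the number holds across this change.

The compounds shown leave open whether a smaller or different group at this place, such as an amine, a nitrile or a methoxy group, would give a comparable number. They also leave open whether the same change would read alike on the cores of compounds 1 and 3.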